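A few compounds are considered here, and "the series" means these few. Any claim that something is new, unique, unknown or untested is made for them only; others in the source may bear on it.

Compound 1 `COc1ccc(-c2cnc3nc(N)nc(N4CCN(C(=O)c5ccccc5)CC4)c3n2)cc1OC` is the stronger of the two measured compounds. In a functional assay on cells (T-cell, Homo sapiens) for inhibition (a lower number here means a stronger inhibitor, a higher number a weaker inhibitor), compound 1 gives 400 nM, the lowest of the two numbers. Compound 2 `CC(C)Oc1nc(N)nc2ncc(-c3ccc(F)c(F)c3)nc12` is the nearest measured neighbour, and in this assay compound 2 gives 10000 nM, a gap to compound 1 that lies beyond the usual scatter; the two compounds differ in more than one place, so nothing more is read from that pair.

Compound 3 `COc1ccc(-c2cnc3nc(N)nc(N4CCN(C(=O)Nc5ccc(F)cc5)CC4)c3n2)cc1OC` differs from compound 1 in one place: (4-fluorophenyl)amino in place of phenyl on a carbonyl carbon. Among the measured compounds shown here, no measured pair shows what this change does in this assay, so the expectation rests on compound 1 alone. The step of no change at the digits printed from compound 1 to compound 3 (within the scatter) is expected to stay within the usual scatter, in no firm direction. Compound 3 is therefore estimated at 400 nM in this assay, with a range from 100 nM to 1600 nM.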

Compound 3, half-maximal inhibitory concentration: 7 nM
The estimate for compound 3 lay 57-fold (1.76 log units) above the measured number; measured number below the stated range.
By their numbers in this assay, from the lowest: compound 3; then compound 1; then compound 2.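

In this assay, the place on a carbonyl carbon whose other neighbour is an amide-type nitrogen in a ring proves highly sensitive: (4-fluorophenyl)amino in place of phenyl gives a 57-fold lower number from compound 1 to compound 3 (1.76 log units; beyond the scatter), a large step beyond the scatter. Compound 1 and compound 2 differ in more than one place and could not show this, whereas this single change shows that the group on the carbonyl carbon strongly governs the inhibition read in cells. Nothing available accounts for the size of this step.

The amino link and the fluorine enter together, so the compounds shown leave open which of them carries the gain. A plain phenylamino group or a 4-fluorophenyl group without the amino link, at the same carbonyl carbon, would separate the two.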